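The source may hold more compounds than are shown below. What is called first, only, known or untested is meant among the compounds shown, and "the series" means these compounds.

Of the compounds shown here, three sharing one core have been measured in a functional assay on DU-145 cells (Homo sapiens) for cytotoxicity, in the presence of a further agent that is not named here; on this read-out lower numbers stand for stronger inhibition and higher numbers for weaker inhibition. Compound 1 `Clc1ccc(-c2cc(-c3ccsc3)nc(-c3ccco3)c2)o1` gives 18900 nM. Compound 2 `Cc1cccc(-c2cc(-c3ccc(Cl)o3)cc(-c3ccsc3)n2)c1` gives 17900 nM. Compound 3 `Clc1ccc(-c2cc(-c3cccnc3)nc(-c3cccs3)c2)o1` gives 13000 nM. On these three numbers compound 3 holds the lowest value, yet its distances to compound 2 and to compound 1 are both within the scatter, so no ranking among the three can be claimed.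

Compound 4 `Clc1ccc(-c2cc(-c3ccco3)nc(-c3cccs3)c2)o1` has not been measured. It differs from compound 3 in one place: furan-2-yl in place of pyridin-3-yl on an aromatic carbon. Of the measured steps, only one bears on this kind of change, the swap of one aromatic group for another on the shared core, and that step, a 1.1-fold lower number from compound 1 to compound 2 (0.02 log units; within the scatter), stayed within the scatter. For the measured compounds named here, that single step is the only guide available; a swap of a six-membered ring with one nitrogen for a five-membered ring with one oxygen has not itself been measured here. On this basis the step from compound 3 to compound 4 in this assay is expected to be small, with no direction that can be called beyond the scatter, as a 1.2-fold higher number from compound 3 to compound 4 (0.06 log units; within the scatter) means to say. Compound 4 is therefore estimated at 15000 nM, with a range from 6000 nM to 40000 nM.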

Compound 4, half-maximal inhibitory concentration: 21800 nM
Beside the measured number, compound 4's estimate is 1.5-fold (0.16 log units) below it; low and high end bracket the measured number.
By their numbers in this assay, from the lowest: compounds 3, 2, 1 and 4 (each within the scatter of the next).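

In this assay, the swap of pyridin-3-yl for furan-2-yl on the aromatic carbon next to the ring nitrogen gives a 1.7-fold higher number from compound 3 to compound 4 (0.22 log units; within the scatter) and so does not separate a six-membered aromatic ring carrying a nitrogen from a five-membered aromatic ring carrying an oxygen at this position. For the compounds shown here, this is the first measured step that changes both the ring size and the hetero atom of the group there, and the earlier compounds offered no such direct test. A second kind of change, thiophen-2-yl in place of thiophen-3-yl, gives a 1.2-fold higher number from compound 1 to compound 4 (0.06 log units; within the scatter) and shows that moving the point of attachment on the same ring also leaves the read-out within the scatter, though no data shown here offer a reason for the small size of either step.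

From the compounds shown here alone, every group varied in these compounds is an aromatic ring, so it remains open whether an amine, a carboxylic acid or a longer alkyl chain on the same carbon would give a step beyond the scatter. All four compounds also keep the 5-chlorofuran-2-yl group, which leaves the effect of changing it unknown.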